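A few compounds are considered here, and "the series" means these few. Any claim that something is new, unique, unknown or untested is made for them only; others in the source may bear on it.

Of the compounds shown here, three sharing one core have been tested in a functional assay on MCF7 cells (Homo sapiens) for cytotoxicity, read by MTT assay, with a stated time of 72 h; a higher number here means that more compound is tolerated, a lower number that less compound is tolerated. Compound 1 `CSc1nc(NCCCc2ccccc2)c2ccccc2n1` sits at the limit of the assay, recorded as > 100000 nM, so only a boundary is known for it. Compound 2 `CSc1nc(NCCCCc2ccccc2)c2ccccc2n1` gives 95900 nM. The step of an at least 1.0-fold lower number from compound 1 to compound 2 (0.01 log units; that floor lies within the scatter) thus leaves the number essentially where it was. Compound 3 `CSc1nc(NCc2ccccc2)c2ccccc2n1` likewise sits at the limit, recorded as > 100000 nM, and no actual number is known for it. Among the measured compounds shown here, compound 4 `CSc1nc(NCCCCCO)c2ccccc2n1` has not yet been measured; it differs from compound 3 by 4-hydroxybutyl in place of phenyl on a saturated chain carbon bound to a nitrogen on an aromatic ring, a change that none of the measured steps resembles. For the measured compounds named here, the only measured step stayed within the scatter, and two of the three values sit at the boundary of the assay (the limit of > 100000 nM in this assay, at which 2 of the 3 values shown sit), so no shift beyond the scatter is expected from this change either. The expected step is therefore a number no higher from compound 3 to compound 4 (the limit leaves the size open), meaning essentially no change. Compound 4 is expected to give about 100000 nM in this assay, somewhere between 50000 nM and 200000 nM, and quite possibly once more reported only as a limit.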

Compound 4, concentration lethal to 50% of the cells: > 100000 nM
Compound 4: no number, only a limit; the forecaster's own chance of this, stated with the estimate: 70%; the middle value sits exactly at the limit.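

Among the compounds shown here, the one readable step, with hydroxymethyl in place of phenyl on a saturated chain carbon, four bonds along the chain from a nitrogen on an aromatic ring, is an at least 1.0-fold higher number from compound 2 to compound 4 (0.01 log units; that floor lies within the scatter); compound 4 is a limit, so this is only a floor. The earlier compounds shown here all carried phenyl at the chain end, while compound 4 has no ring there and ends in a hydroxyl group, yet this change gives no shift that can be told from the scatter. The steps to compound 4 from compound 3 and from compound 1 cannot be read, because both ends of each sit at the same boundary: the limit of > 100000 nM in this assay, at which 3 of the 4 values shown sit.

Going by these compounds, how far the true value of compound 4 lies from that of compound 2 in this assay stays unknown. Also open, on these data alone, is whether an amine or a carboxylic acid at this chain end would give a real number well below the limit.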